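Two Measured Compounds and One Awaiting a Number

The source may hold more compounds than are shown below. What is called first, only, known or untested is meant among the compounds shown, and "the series" means these compounds.

Compound 1 `COc1ccc(-c2nc(CN)sc2-c2ccc(OC)cc2)cc1`: 7.7 uM
Compound 2 `COc1ccc(-c2nc(C(=O)N3CCNC(CCO)C3)sc2-c2ccc(OC)cc2)cc1`: 9.5 uM

In a functional assay (aorta) with Rattus norvegicus as the target (a higher number here means that more compound is needed for the effect, a lower number that less compound is needed), compound 1 gives 7.7 uM, the lowest of the two numbers, while compound 2 gives 9.5 uM, a gap that lies within the usual scatter, so no order can be read between them. Compound 3 `CCOC(=O)/C(C#N)=C/c1nc(-c2ccc(OC)cc2)c(-c2ccc(OC)cc2)s1` differs from compound 1 by 2-cyano-2-(ethoxycarbonyl)ethenyl in place of aminomethyl on an aromatic carbon. For the measured compounds named here, no step between measured compounds is on record, so nothing here shows how this assay answers a change of this kind. The step from compound 1 to compound 3 is therefore expected to be small, a 1.3-fold higher number from compound 1 to compound 3 (0.11 log units; within the scatter), in either direction or none beyond the scatter. Compound 3 is estimated at 10 uM, between 3 uM and 30 uM.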

Compound 3, concentration for half-maximal effect: > 100 uM
Compound 3: a limit, no number (the forecaster's own chance of this, stated with the estimate: 15%); middle value at least 10-fold (1.00 log units) away from the limit.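

On the aromatic carbon next to the ring nitrogen and the ring sulfur, 2-cyano-2-(ethoxycarbonyl)ethenyl in place of aminomethyl gives an at least 12-fold higher number from compound 1 to compound 3 (1.11 log units; beyond the scatter). For the compounds shown here, with no step on record before, this is the first sign that a change at this position can matter in this assay. Compound 3 gives a limit, not a number: the limit of > 100 uM in this assay, at which 1 of the 3 values shown sits.

As far as these compounds go, what remains open is whether the loss of the aminomethyl group or some part of the entering group, such as its nitrile or ethyl ester, accounts for this step. From the compounds shown here alone, how an aminoethyl chain or a carboxylic acid at this position would read also remains unknown.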